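This account rests on a few compounds, and the source may have more. Where it says the series, first, only, none or still open, it means among the compounds named here.

In a functional assay on the whole organism with Mus musculus as the target (a higher number here means that more compound is needed for the effect, a lower number that less compound is needed), compound 1 `CNC(=O)/C(C)=C/c1cccc(C(F)(F)F)c1` gives 75 mg/kg. Compound 2 `O=C1CCC(O)(c2cccc(C(F)(F)F)c2)N1` gives only a limit of the assay, > 200 mg/kg. Compound 3 `CN1C(=O)CCC1(O)c1cccc(C(F)(F)F)c1` gives 93.8 mg/kg, within the scatter of compound 1. Compound 4 `CCN1C(=O)CCC1(O)c1cccc(C(F)(F)F)c1` differs from compound 3 by methyl in place of hydrogen on a saturated chain carbon bound to an amide-type nitrogen in a ring, or methyl to ethyl. Among the compounds with values here, the one measured step that bears on this is an at least 2.1-fold lower number from compound 2 to compound 3 (0.32 log units; beyond the scatter). That step put a methyl on the nitrogen itself, whereas this one extends that group, so it is only a loose guide. The expected change is small, a 1.2-fold lower number from compound 3 to compound 4 (0.07 log units; within the scatter), with no shift beyond the scatter. For compound 4 the estimate is 80 mg/kg, with an expected range from 40 mg/kg to 160 mg/kg.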

Compound 4, dose for half-maximal effect: > 100 mg/kg
Compound 4 gave a limit, no number; the forecaster's own chance of this, stated with the estimate: 10%; middle value at least 1.2-fold (0.09 log units) from the limit.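

Going from methyl to ethyl on the amide-type nitrogen in a ring gives an at least 1.0-fold higher number from compound 3 to compound 4 (0.02 log units; that floor lies within the scatter) in this assay. The lower number seen when methyl replaced hydrogen on that nitrogen, an at least 2.1-fold lower number from compound 2 to compound 3 (0.32 log units; beyond the scatter), is thus not shown to continue with ethyl, and only a floor of the new step is known. The step between compound 2 and compound 4 cannot be read, as both values are limits.

As far as these compounds go, what a longer chain, or a chain carrying an amine or a carboxylic acid, on that nitrogen would do stays open.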